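A Mirror Image of Compound 2 in the Circulation

The source may report more compounds than this note shows. Statements on the series, on what has been measured and on what is new or still open speak of the compounds shown alone.

- compound 1 `CN(CCCNC(=O)Nc1ccc(C(C)(C)C)cc1)C[C@H]1C[C@@H](c2ccc3c(N)ncnn23)[C@H](O)[C@@H]1O` gives 3080 ng.h/mL as its measured value
- compound 2 `CC(C)NC[C@@H]1C[C@H](c2ccc3c(N)ncnn23)[C@@H](O)[C@H]1O` gives 7250 ng.h/mL as its measured value

In an ADME assay on the whole organism (Mus musculus, strain BALB/c) for pharmacokinetics, read by LC-MS, with a stated time of 600 min, at a dose of 20 mg/kg by the intravenous route (a lower number here means less compound in the circulation, a higher number more compound in the circulation at the dose given), compound 2 holds the higher of the two numbers at 7250 ng.h/mL and the gap down to compound 1 at 3080 ng.h/mL lies beyond the scatter of repeat measurements.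

Compound 3 `CC(C)NC[C@H]1C[C@@H](c2ccc3c(N)ncnn23)[C@H](O)[C@@H]1O` has not been measured yet. Going by the values given here, its only change from compound 2 is one of configuration (the two compounds have the same atoms and bonds and differ only in configuration as drawn: 4 of 4 stereo elements differ (all stereocentres are inverted: mirror images); a stereocentre at a saturated ring carbon is drawn S in compound 2 and R in compound 3; a stereocentre at a saturated ring carbon is drawn R in compound 2 and S in compound 3; a stereocentre at a saturated ring carbon is drawn R in compound 2 and S in compound 3; a stereocentre at a saturated ring carbon is drawn S in compound 2 and R in compound 3), so the two compounds have the same atoms and bonds and are mirror images. Mirror images can behave differently in a living animal, but no measured pair of this kind is available here to show how far apart they might fall. A small downward step is therefore expected, one that does not go beyond the scatter. The expected step is a 1.3-fold lower number from compound 2 to compound 3 (0.12 log units; within the scatter) and this estimate carries wide uncertainty. For compound 3 the expected value in this assay is 5500 ng.h/mL with a range from 2200 ng.h/mL to 12000 ng.h/mL as estimated.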

Compound 3, area under the concentration-time curve: 14200 ng.h/mL
Estimate against measurement, compound 3: 2.6-fold (0.41 log units) below, outside the stated range (above it).
By their numbers in this assay, from the lowest: compound 1; then compounds 2 and 3 (each within the scatter of the next).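

Inverting all four stereocentres at once, the one change that no earlier comparison offered, gives a 2.0-fold higher number from compound 2 to compound 3 (0.29 log units; within the scatter) in this assay. Exposure in the circulation therefore does not separate this mirror-image pair beyond what repeat measurements would scatter, so this single pair gives no sign that the drawn configuration of the shared core matters for this read-out in the mouse. Whatever small difference the numbers hold, only one structural feature is available to tie it to: the fact that compounds 2 and 3 differ only in the configuration as drawn.

Going by these compounds alone, what remains open is whether inverting just one of the four stereocentres, rather than all of them, would stay equally within the scatter, and whether the same holds for other mirror-image pairs, since this is the only pair of its kind here. Also open, as far as these compounds go, is whether the configuration would count for more if the side chain of compound 2 carried a different group, such as a carboxylic acid or a longer chain, in place of its isopropyl amine.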